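The compounds below may be only part of what the source reports. "The series", "measured", "known", "first", "only" and "open" are said of these compounds alone.

Measured so far:
Compound 1 `O=C1C[C@@H]2O[C@@H](Cc3ccccc3)[C@@H](O)[C@@H]2O1`: 1210 nM
Compound 2 `O=C1C[C@H]2O[C@H](Cc3ccccc3)[C@H](OCc3ccccc3)[C@H]2O1`: 4320 nM
Compound 3 `O=C1C[C@@H]2O[C@H]3[C@H](c4ccccc4)c4ccccc4CO[C@H]3[C@@H]2O1`: 6560 nM

All three compounds were tested in a functional assay on HeLa cells (Homo sapiens) for antiproliferative activity, read by MTT assay, with a stated time of 72 h; on this read-out higher numbers stand for weaker inhibition and lower numbers for stronger inhibition. In this assay compound 2 gives 4320 nM. That number lies within the scatter of the number for compound 3, while compound 1 shows a lower number, beyond the scatter.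

Compound 4 `O=C1C[C@H]2O[C@H](Cc3ccccc3)[C@H](O)[C@H]2O1` has not yet been measured. It differs from compound 2 by hydrogen in place of benzyl on an oxygen on a saturated carbon, or benzyloxy to hydroxy. Among the measured compounds shown here, no measured pair shows this change on its own, and its size cannot be read directly from the data.

For the measured compounds named here, the nearest guide is compound 1 at 1210 nM, the only measured compound carrying a hydroxy group. It is a loose guide, since it is drawn as the mirror image of compound 4. A moderate move towards a lower number is expected in this assay, near the edge of the scatter or somewhat beyond it, although no real change cannot be ruled out. The expected step is a 2.4-fold lower number from compound 2 to compound 4 (0.38 log units; beyond the scatter). For compound 4 the estimate is 1800 nM, with an expected range of 400 nM to 8000 nM.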

Compound 4, half-maximal inhibitory concentration: 4420 nM
Compound 4: middle estimate off by 2.5-fold (0.39 log units), on the low side, and the stated range covers the measured number.
By their numbers in this assay, from the lowest: compound 1; then compounds 2, 4 and 3 (each within the scatter of the next).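

In this assay, putting hydrogen in place of benzyl on an oxygen on a saturated carbon gives a 1.0-fold higher number from compound 2 to compound 4 (0.01 log units; within the scatter), so with this configuration of the core the assay cannot tell the free hydroxy compound from the benzyl ether. Configuration, by contrast, does register at the level of the whole molecule: the mirror-image pair shows a 3.7-fold higher number from compound 1 to compound 4 (0.56 log units; beyond the scatter), and this is the only one of the two steps that lies beyond the scatter. This gap can be traced to the drawn configuration alone, as no atom or bond differs within the pair, and it arises because: the fact that compounds 1 and 4 differ only in the configuration as drawn

The compounds shown leave open whether the same benzyl-to-hydrogen change would be equally silent on the mirror-image core of compound 1, where the hydroxy compound gives the lower number. They also leave open whether this tolerance holds for other groups on that oxygen, such as a methyl ether, an acetyl ester or a longer chain carrying an amine, since benzyl and hydrogen are the only two compared directly here.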